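The compounds below may be only part of what the source reports. "The series", "measured", "known", "first", "only" and "open" are said of these compounds alone.

Measured in a functional assay on A549 cells (Homo sapiens) for cytotoxicity, read by MTT assay, with a stated time of 48 h; a higher number here means a weaker inhibitor, a lower number a stronger inhibitor:
- compound 1 `COc1cc(-n2c(-c3ccccc3)cn(C(C)=O)c2=O)cc(OC)c1OC`: > 50000 nM (a limit of the assay)
- compound 2 `COc1cc(-n2c(-c3ccc(F)cc3F)cn(C(C)=O)c2=O)cc(OC)c1OC`: 24100 nM
- compound 3 `COc1ccc(-c2cn(C(C)=O)c(=O)n2-c2cc(OC)c(OC)c(OC)c2)cc1[N+](=O)[O-]`: 40900 nM

Compound 3, at 40900 nM, lies within the scatter of compound 2, at 24100 nM. Compound 4 `COc1ccc(-c2cn(C(C)=O)c(=O)n2-c2cc(OC)c(OC)c(OC)c2)cc1N` differs from compound 3 by amino in place of nitro on an aromatic carbon, ortho to a methoxy group: amino in place of nitro on an aromatic carbon. Among the measured compounds shown here, the only measured step, an at least 2.0-fold lower number from compound 1 to compound 2 (0.31 log units; beyond the scatter), is a different change, and no measured step touches the nitro group. It therefore offers only a rough size, so a modest move towards a lower number in this assay is expected, with wide uncertainty. The expected change is a 5.1-fold lower number from compound 3 to compound 4 (0.71 log units; beyond the scatter). For compound 4 the estimate is 8000 nM, with an expected range from 500 nM to 45000 nM.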

Compound 4, half-maximal inhibitory concentration: 1100 nM
For compound 4 the middle estimate is 7.3-fold (0.86 log units) above the measured one; measured number inside the range.
By their numbers in this assay, from the lowest: compound 4; then compounds 2 and 3 (each within the scatter of the next). At a limit, above all of these: compound 1.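

Replacing nitro with amino, ortho to a methoxy group, gives a 37-fold lower number from compound 3 to compound 4 (1.57 log units; beyond the scatter) in this assay, so this position responds strongly to this change. The 3-amino-4-methoxyphenyl group also compares well with 2,4-difluorophenyl, giving a 22-fold lower number from compound 2 to compound 4 (1.34 log units; beyond the scatter). Against phenyl, the step of an at least 45-fold lower number from compound 1 to compound 4 (1.65 log units; beyond the scatter) is only a bound, since compound 1 stands at a limit of the assay: the limit of > 50000 nM in this assay, at which 1 of the 4 values shown sits.

The compounds shown leave open whether the drop needs a free amine or would persist with a hydroxyl or methylamino group at this position. They also leave open whether the neighbouring methoxy group is required.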